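The compounds below may be only part of what the source reports. "The series", "measured", "known", "first", "only" and "open" are said of these compounds alone.

Compound 1 `O=C(NCCCCN1CCCCC1)Nc1ccc(-c2ccccn2)nc1` carries a pyridin-2-yl group on the shared core. In a functional assay on HEK293 cells for agonist activity at 5-hydroxytryptamine receptor 3A (Homo sapiens), read by FLIPR (a higher number here means a weaker inhibitor, a lower number a stronger inhibitor), compound 1 gives > 30000 nM, and this is a limit of the assay rather than a measured number. Compound 1 therefore stands at the limit of > 30000 nM in this assay, at which 1 of the 2 values shown sits, so its true potency is known only to lie beyond that boundary. Compound 2 `COc1ccccc1-c1ccc(NC(=O)NCCCCN2CCCCC2)cc1` carries a different aromatic end on a different core, and in this assay compound 2 gives 7800 nM, an actual number. Going by the values given here, compound 1 and compound 2 differ in more than one place, so no single step between them is counted; the two values show only that one reads as a limit and the other as a number.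

Compound 3 `O=C(NCCCCN1CCCCC1)Nc1ccc(-c2ccccc2F)nc1` has not yet been measured. It differs from compound 1 in one place: 2-fluorophenyl in place of pyridin-2-yl on an aromatic carbon. Because compound 1 sits at the limit of > 30000 nM in this assay, at which 1 of the 2 values shown sits, the size of this step cannot be read from the values shown. A moderate move toward lower numbers is expected, and the expected step is an at least 2.0-fold lower number from compound 1 to compound 3 (0.30 log units; that floor lies within the scatter) in this assay. Compound 3 is estimated at 15000 nM, with a range from 4000 nM to 60000 nM.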

Compound 3, half-maximal inhibitory concentration in the 5-hydroxytryptamine receptor 3A assay: > 30000 nM
Compound 3: only a limit was reported (the forecaster's own chance of this, stated with the estimate: 35%); middle value at least 2.0-fold (0.30 log units) away from the limit.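

In the 5-hydroxytryptamine receptor 3A assay compound 3 gives > 30000 nM, which is a limit of the assay and not a number. In the 5-hydroxytryptamine receptor 3A assay compound 1 gives > 30000 nM, which is also a limit of the assay and not a number. No step between compound 1 and compound 3 can be read: the limit of > 30000 nM in the 5-hydroxytryptamine receptor 3A assay, at which 2 of the 3 values shown sit.

The compounds shown leave open how far the true potency of each lies beyond that limit, and whether the two differ at all.

In a physicochemical assay for solubility, at pH 7.4 (a lower number here means a less soluble compound, a higher number a more soluble compound), compound 1 gives 171000 nM and compound 3 gives 196000 nM as measured numbers. In the physicochemical assay 2-fluorophenyl in place of pyridin-2-yl gives a 1.1-fold higher number from compound 1 to compound 3 (0.06 log units; within the scatter) and the two values cannot be told apart.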